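The source may report more compounds than this note shows. Statements on the series, on what has been measured and on what is new or still open speak of the compounds shown alone.

Working notes on the series: in an ADME assay on liver (Mus musculus) for metabolic stability, read by LC-MS, using microsomes and NADPH (on this read-out lower numbers stand for a less stable compound and higher numbers for a more stable compound), compound 1 `CCN(Cc1ccc(OCCN2C(=O)CCC2=O)c(C)c1)C(CC(=O)O)c1ccc(Cl)cc1` gives 88%, the higher of the two readings so far. Compound 2 `Cc1cc(CN(CC2CCCC2)[C@@H](CC(=O)O)c2ccc(Cl)cc2)ccc1OCCN1C(=O)CCC1=O` gives 69%, a gap beyond the scatter. Compound 3 `Cc1cc(CN(CC2CCCCC2)C(CC(=O)O)c2ccc(Cl)cc2)ccc1OCCN1C(=O)CCC1=O` differs from compound 1 by cyclohexyl in place of methyl on a saturated chain carbon bound to an amine nitrogen. Within the data shown here, no measured step covers this change, so the expectation leans on the lower reading of compound 2 at 69%. The expected change is a number 26 percentage points lower from compound 1 to compound 3 (beyond the scatter), a fall beyond the scatter in this assay. For compound 3 the estimate is 62%, with an expected range of 42% to 80%.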

Compound 3, percent of the compound remaining: 57%
The estimate for compound 3 lay 5 percentage points above the measured number, and the stated range covers the measured number.
By their numbers in this assay, from the lowest: compound 3; then compound 2; then compound 1.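

In this assay, among these compounds, cyclohexyl in place of methyl on a saturated chain carbon bound to an amine nitrogen gives the first single-place step, a large one: a number 31 percentage points lower from compound 1 to compound 3 (beyond the scatter). The number at this position therefore responds to the group it carries while the rest of the core of compound 1 stays the same. Nothing available bears on the reason for this fall. Still open, going by these compounds, is where a propyl chain would fall on this read-out, and whether a tetrahydropyranyl ring, with oxygen in the six-membered ring, would read like cyclohexyl.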